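Three aryl-sulfonamide piperidines at the cytotoxicity limit

The compounds below may be only part of what the source reports. "The series", "measured", "known", "first", "only" and "open" are said of these compounds alone.

Compound 1 `CC1CCN(C2CCN(S(=O)(=O)c3cccc(-c4ccccc4C(F)(F)F)c3)CC2)CC1` carries a 2-(trifluoromethyl)phenyl group on its shared core. In an ADME assay on HCT-116 cells (Homo sapiens) for cytotoxicity, read by CellTiter-Glo, with a stated time of 72 h (on this read-out higher numbers stand for weaker inhibition and lower numbers for stronger inhibition), compound 1 gives > 5000 nM, which is a limit of the assay rather than a number. Compound 2 `COc1ccccc1-c1cccc(S(=O)(=O)N2CCC(N3CCC(C)CC3)CC2)c1` differs by methoxy in place of trifluoromethyl on an aromatic carbon; in this assay compound 2 gives > 5000 nM, again a limit. Compound 3 `CC1CCN(C2CCN(S(=O)(=O)c3cccc(-c4ccc(F)cc4)c3)CC2)CC1` carries a 4-fluorophenyl group instead; in this assay compound 3 gives > 5000 nM, also a limit. The three steps, a step that the two limits leave unreadable from compound 1 to compound 2, a step that the two limits leave unreadable from compound 1 to compound 3 and a step that the two limits leave unreadable from compound 2 to compound 3, cannot be read because every value sits at the limit of > 5000 nM in this assay, at which 3 of the 3 values shown sit. Compound 3 therefore stands at the same limit as the others.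

Compound 4 `Cc1ccc(-c2cccc(S(=O)(=O)N3CCC(N4CCC(C)CC4)CC3)c2)cc1` differs from compound 3 by methyl in place of fluoro on an aromatic carbon. Every measured step here is unreadable, so none points to a change of size. The step that the limit leaves unreadable from compound 3 to compound 4 is expected to stay within the scatter. Compound 4 is expected to give 8000 nM, between 3000 nM and 30000 nM.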

Compound 4, half-maximal inhibitory concentration: > 5000 nM
Compound 4 was reported as a limit; the forecaster's own chance of this, stated with the estimate: 80%; the middle value lies beyond the limit too.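

No new step can be read from compound 4 to compound 1, compound 2 or compound 3, because each value is a limit and not a number: the limit of > 5000 nM in this assay, at which 4 of the 4 values shown sit.

The compounds shown leave open how these four compare in this assay, and whether any change on the shared core gives a readable value.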